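A few compounds are considered here, and "the series" means these few. Any claim that something is new, unique, unknown or untested is made for them only; others in the source may bear on it.

Series notes. Compound 1 `CCN(CC)S(=O)(=O)c1ccc(S(=O)(=O)N2CCC[C@@H](C(=O)N3CCC(F)(F)CC3)C2)cc1` pairs a diethylsulfamoyl group on the shared core with a 4,4-difluoropiperidin-1-yl amide; in a functional assay on MIA PaCa-2 cells (Homo sapiens) for inhibition, read by MTT assay, with a stated time of 7 days (a higher number here means a weaker inhibitor, a lower number a stronger inhibitor), compound 1 gives 16 nM, the lowest number among the three measured compounds. Compound 2 `CCN(CC)S(=O)(=O)c1ccc(S(=O)(=O)N2CCC[C@@H](C(=O)N3CCC(C(F)(F)F)CC3)C2)cc1` gives 320 nM in this assay, and compound 3 `CCN(CC)S(=O)(=O)c1ccc(S(=O)(=O)N2CCC[C@@H](C(=O)N3CCOCC3)C2)cc1` gives 350 nM. The steps of a 20-fold higher number from compound 1 to compound 2 (1.30 log units; beyond the scatter) and a 22-fold higher number from compound 1 to compound 3 (1.34 log units; beyond the scatter) are both large, whereas a 1.1-fold higher number from compound 2 to compound 3 (0.04 log units; within the scatter) lies within the scatter. Every measured step concerns the amide partner on the carbonyl carbon; the sulfonyl end of the molecule is the same in all three.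

Compound 4 `CC(C)S(=O)(=O)c1ccc(S(=O)(=O)N2CCC[C@@H](C(=O)N3CCC(F)(F)CC3)C2)cc1` alters that other end: isopropyl in place of diethylamino on a sulfonyl sulfur. Among the measured compounds shown here, no measured step touches the sulfonyl sulfur, so nothing sizes this change. The expectation for compound 4 in this assay therefore rests on compound 1 alone, which gave 16 nM and whose amide partner is retained. For the measured compounds named here, with no comparable step to draw on, the estimated shift a 1.9-fold higher number from compound 1 to compound 4 (0.27 log units; within the scatter) is kept small, with neither direction preferred and a wide band around it. Compound 4 is estimated at 30 nM, within 6 nM to 160 nM.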

Compound 4, half-maximal inhibitory concentration: 11 nM
Compound 4: middle estimate off by 2.7-fold (0.44 log units), on the high side; low and high end bracket the measured number.
By their numbers in this assay, from the lowest: compounds 4 and 1 (each within the scatter of the next); then compounds 2 and 3 (each within the scatter of the next).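

In this assay the sulfonyl end now has its first measured step, and a 1.5-fold lower number from compound 1 to compound 4 (0.16 log units; within the scatter) shows that isopropyl in place of diethylamino on a sulfonyl sulfur, with the 4,4-difluoropiperidin-1-yl amide retained, leaves the number within the scatter. At this place, then, the diethylsulfamoyl group is not required for a low number in this pair, as the isopropylsulfonyl group serves equally well within the scatter. This contrasts with the amide partner, where a 20-fold higher number from compound 1 to compound 2 (1.30 log units; beyond the scatter) and a 22-fold higher number from compound 1 to compound 3 (1.34 log units; beyond the scatter) are both large steps, so in these compounds the number moves with the amide partner and not with this single sulfonyl change. No measured evidence is available to explain the result.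

Going by these compounds, the sulfonyl change has been read on the 4,4-difluoropiperidin-1-yl amide alone, so it remains open whether it would also leave the number within the scatter alongside a morpholin-4-yl or 4-(trifluoromethyl)piperidin-1-yl amide. Also open, on these data alone, is how the number would respond to other groups on the sulfonyl sulfur, such as a cyclopropyl ring, a piperidin-1-yl ring, a longer chain such as n-butyl, or a chain ending in a primary amine.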